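Swapping Hydroxy for Trifluoromethyl on an Amide Partner

The compounds below may be only part of what the source reports. "The series", "measured", "known", "first", "only" and "open" are said of these compounds alone.

Compound 1 `O=C(Nc1ccccc1O)c1nccc2ccccc12` is an amide whose aryl partner carries a hydroxy group. In a functional assay on NUGC-3 cells (Homo sapiens) for inhibition, read by sulforhodamine B assay, with a stated time of 48 h (a lower number here means a stronger inhibitor of growth, a higher number a weaker inhibitor of growth), compound 1 gives > 10000 nM, which is a limit of the assay rather than a number. In this assay compound 2 `COc1ccc(NC(=O)C2NCCc3ccccc32)cc1` gives > 10000 nM, again only a limit. In this assay compound 3 `O=C(Nc1cc(C(F)(F)F)cc(C(F)(F)F)c1)C1NCCc2ccccc21` gives > 10000 nM, a limit as well. All three values therefore sit at the limit of > 10000 nM in this assay, at which 3 of the 3 values shown sit. Compound 4 `O=C(Nc1ccccc1C(F)(F)F)c1nccc2ccccc12` differs from compound 1 by trifluoromethyl in place of hydroxy on an aromatic carbon. Going by the values given here, no measured pair shows such a change, so in this assay the step to compound 4 is expected to be none beyond the scatter, with a weak result most likely. Compound 4 is expected to give about 15000 nM, between 3000 nM and 60000 nM. This estimate implies a step that the limit leaves unreadable from compound 1 to compound 4.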

Compound 4, concentration for 50% growth inhibition: > 10000 nM
Compound 4: only a limit was reported (the forecaster's own chance of this, stated with the estimate: 75%); the middle value lies beyond the limit too.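

Compound 1 and compound 4 both rest at a limit of the assay, so no step can be read for trifluoromethyl in place of hydroxy. The compounds shown leave open which structure, if any, gives a measurable value in this assay.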